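Swapping chloro for bromo on a chalcone-like scaffold

The source may report more compounds than this note shows. Statements on the series, on what has been measured and on what is new or still open speak of the compounds shown alone.

Of the compounds shown here, three share a core and have been tested in a functional assay on PC-3 cells (Homo sapiens), read by fluorescence and BrdU incorporation, with a stated time of 48 h, tested at 25 uM; a higher number here means a weaker effect of the compound at the concentration tested, a lower number a stronger effect. Compound 1 `COc1cc(O)c(C(=O)/C=C/c2ccc(F)cc2)c(OC)c1` gives 34%. Compound 2 `COc1cccc(/C=C/C(=O)c2c(OC)cc(OC)cc2OC)c1` gives 0.9%. Compound 3 `COc1cc(OC)c(C(=O)/C=C/c2ccc(Cl)cc2)c(OC)c1` gives 0.2%, the lowest of the three numbers: its gap to compound 2 lies within the scatter, while its gap to compound 1 lies well beyond it.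

The next compound, compound 4 `COc1cc(OC)c(C(=O)/C=C/c2ccc(Br)cc2)c(OC)c1`, differs from compound 3 in one place: bromo in place of chloro on an aromatic carbon. For the measured compounds named here, the only measured step that touches the same position is a number 0.7 percentage points lower from compound 2 to compound 3 (within the scatter), where exchanging the whole aromatic substituent left the number essentially unchanged. Exchanging one halogen for another at that same place is a smaller change than that, so no step beyond the scatter is expected in this assay; the estimated step is a number 0.3 percentage points higher from compound 3 to compound 4 (within the scatter).

Compound 4 is therefore expected to give about 0.5%, with a plausible range from 0% to 8%.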

Compound 4, a percentage reported as activity, at one concentration (the size of the read-out at that concentration, not a potency): 0.4%
The estimate for compound 4 lay 0.1 percentage points above the measured number, and the stated range covers the measured number.
By their numbers in this assay, from the lowest: compounds 3, 4 and 2 (each within the scatter of the next); then compound 1.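

For the compounds shown here, earlier, the only step at this position exchanged a whole aromatic substituent; here only the halogen changes, and in this assay bromo in place of chloro gives a number 0.2 percentage points higher from compound 3 to compound 4 (within the scatter) on the shared core. The 4-bromophenyl group also shows no separable difference from the 3-methoxyphenyl group, with a number 0.5 percentage points lower from compound 2 to compound 4 (within the scatter) in the same assay, so the three substituents at this place on compounds 2, 3 and 4 now all lie within the scatter of one another. No measurement at hand explains why the number holds across these changes.

From the compounds shown here alone, whether an amine or a carboxylic acid on this aromatic carbon would leave the number unchanged remains open. Compound 1 differs from the others in more than one place, so the separate contributions of its fluoro and hydroxyl groups cannot be read.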